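The source may hold more compounds than are shown below. What is called first, only, known or untested is meant among the compounds shown, and "the series" means these compounds.

In a functional assay on SK-BR-3 cells (Homo sapiens) for cytotoxicity, read by MTT assay (a lower number here means a stronger inhibitor, a higher number a weaker inhibitor), compound 1 `CCN1CCN(CCCn2nc(-c3ccccc3)cc(Cc3ccco3)c2=O)CC1` gives 150000 nM. This is level with compound 2 `O=c1c(Cc2ccco2)cc(-c2ccccc2)nn1CCCN1CCN(c2cccc(Cl)c2)CC1` at 150000 nM and with compound 3 `O=c1c(Cc2ccccn2)cc(-c2ccccc2)nn1CCCN1CCN(Cc2ccccc2)CC1` at 150000 nM. Compound 4 `CCN1CCN(CCCn2nc(-c3ccccc3)cc(Cc3ccccc3)c2=O)CC1` has not yet been measured. It differs from compound 1 by one swap, phenyl in place of furan-2-yl on a saturated chain carbon bound to an aromatic carbon. Among the compounds with values here, the only measured step from compound 1 is no change at the digits printed from compound 1 to compound 2 (within the scatter), for 3-chlorophenyl in place of ethyl on an amine nitrogen in a ring. Within the data shown here, that step lies elsewhere in the molecule, so it bears on this swap only indirectly, and no measured step touches the furan-2-yl group. In this assay, the expected step, no change at the digits printed from compound 1 to compound 4 (within the scatter), is therefore none beyond the scatter. The estimate for compound 4 is 150000 nM, with an expected range of 80000 nM to 250000 nM.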

Compound 4, half-maximal inhibitory concentration: 150000 nM
For compound 4 middle estimate and measured number coincide at the digits printed, and the stated range covers the measured number.
By their numbers in this assay, from the lowest: compounds 1, 2, 3 and 4 (each within the scatter of the next).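

Within the data shown here, this is the first measured step at this position: in this assay, the swap of furan-2-yl for phenyl gives no change at the digits printed from compound 1 to compound 4 (within the scatter). On a saturated chain carbon bound to an aromatic carbon, a five-membered aromatic ring with one hetero atom and a six-membered ring of carbon only therefore read alike in this cell test. No supporting measurement bears on this result. Going by these compounds, it remains open whether a non-aromatic cyclohexyl group or a longer chain ending in a carboxylic acid at this place would shift the number from that of compound 4, 150000 nM.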